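From compound 3 to the nitrile compound 4

The source may hold more compounds than are shown below. What is called first, only, known or untested is meant among the compounds shown, and "the series" means these compounds.

Measured so far in a functional assay for inhibition, with Homo sapiens as the target; on this read-out lower numbers stand for stronger inhibition and higher numbers for weaker inhibition
Compound 1 `O=C(O)CCCCCCCCn1nc(-c2ccccc2)c(-c2ccccc2)c1-c1ccccc1` gives 400 nM
Compound 2 `CC(C)(C)OC(=O)COCCCCCCn1nc(-c2ccccc2)c(-c2ccccc2)c1-c1ccccc1` gives only a limit, > 62000 nM
Compound 3 `O=C(O)CSCCCCCCn1nc(-c2ccccc2)c(-c2ccccc2)c1-c1ccccc1` gives 870 nM

Of the two values that are actual numbers, compound 3 has the higher, and a 2.2-fold higher number from compound 1 to compound 3 (0.34 log units; beyond the scatter) is a modest step. In compound 4 `N#CCCCCCCCCn1nc(-c2ccccc2)c(-c2ccccc2)c1-c1ccccc1` the change is 2-cyanoethyl in place of (carboxymethyl)sulfanyl on a saturated chain carbon, six bonds along the chain from an aromatic nitrogen and reads 2-cyanoethyl in place of (carboxymethyl)sulfanyl on a saturated chain carbon, six bonds along the chain from an aromatic nitrogen. Among the measured compounds shown here, compound 4, like compound 2, has no free carboxyl group, so the steps that bear on it are an at least 71-fold lower number from compound 2 to compound 3 (1.85 log units; beyond the scatter) and an at least 150-fold higher number from compound 1 to compound 2 (2.19 log units; beyond the scatter), both large. The expected change is a 34-fold higher number from compound 3 to compound 4 (1.54 log units; beyond the scatter) and it would be large, towards a higher number. A limit in place of a number would be no surprise. For compound 4 the estimated value is 30000 nM with an expected range from 5000 nM to 100000 nM.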

Compound 4, half-maximal inhibitory concentration: > 72000 nM
Compound 4 was reported as a limit (the forecaster's own chance of this, stated with the estimate: 55%); at least 2.4-fold (0.38 log units) between middle value and limit.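

In this assay, compound 4 is reported only as a limit: the limit of > 72000 nM in this assay, at which 1 of the 4 values shown sits. Cyano in place of carboxy, eight bonds along the chain from an aromatic nitrogen, brings an at least 180-fold higher number from compound 1 to compound 4 (2.25 log units; beyond the scatter), and 2-cyanoethyl in place of (carboxymethyl)sulfanyl brings an at least 82-fold higher number from compound 3 to compound 4 (1.91 log units; beyond the scatter). Among these four compounds, only those with a free carboxy group give actual numbers, and the step between compound 2 and compound 4 cannot be read because both are limits.

As far as these compounds go, whether a primary amide or a tetrazole at the chain end could stand in for the carboxylic acid remains open. So does how a shorter or longer acid chain would read.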